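Replacing the methoxypyridine arm: a step to compound 3

A few compounds are considered here, and "the series" means these few. Any claim that something is new, unique, unknown or untested is made for them only; others in the source may bear on it.

Compound 1: `COc1ccc(-c2ccc(OCc3cc(C(=O)NS(=O)(=O)c4ccccc4)oc3C)cc2)cc1` — 5 nM
Compound 2: `COc1ccc(-c2ccc(OCc3cc(C(=O)NS(=O)(=O)c4ccccc4)oc3C)cc2)nc1` — 22 nM

Of the compounds shown here, two have been measured in an assay on cells for displacement of a labelled ligand from prostaglandin E2 receptor EP4 subtype (Homo sapiens), read by scintillation counting; a lower number here means a stronger inhibitor, a higher number a weaker inhibitor. Compound 1 `COc1ccc(-c2ccc(OCc3cc(C(=O)NS(=O)(=O)c4ccccc4)oc3C)cc2)cc1` gives 5 nM, and compound 2 `COc1ccc(-c2ccc(OCc3cc(C(=O)NS(=O)(=O)c4ccccc4)oc3C)cc2)nc1` gives 22 nM. Among the compounds with values here, the one measured step, a 4.4-fold higher number from compound 1 to compound 2 (0.64 log units; beyond the scatter), exchanges the outer ring of compound 1 for a nitrogen-containing one. Within the data shown here, compound 2 therefore stands at the higher of the two numbers, with compound 1 as its only neighbour.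

Compound 3 `Cc1oc(C(=O)NS(=O)(=O)c2ccccc2)cc1COc1ccc(-c2ccc(OC(F)F)cc2)cc1` differs from compound 2 in one place: 4-(difluoromethoxy)phenyl in place of 5-methoxypyridin-2-yl on an aromatic carbon. Among the measured compounds shown here, this change runs partly against the direction of the measured step, since it returns to a ring of carbon only while also exchanging methoxy for difluoromethoxy; the second part has no measured counterpart here. Given that compound 1 gave 5 nM, compound 3 is expected to land nearer that number, an estimated step of a 2.8-fold lower number from compound 2 to compound 3 (0.44 log units; beyond the scatter). The estimate for compound 3 in this assay is 8 nM, within a range of 3 nM to 25 nM.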

Compound 3, inhibition constant: 1.3 nM
For compound 3 the middle estimate is 6.2-fold (0.79 log units) above the measured one, and the stated range ends above it.
By their numbers in this assay, from the lowest: compound 3; then compound 1; then compound 2.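

In this assay, the exchange of 5-methoxypyridin-2-yl for 4-(difluoromethoxy)phenyl gives a 17-fold lower number from compound 2 to compound 3 (1.23 log units; beyond the scatter) and so more than reverses the loss seen on going to the pyridine ring, leaving compound 3 with the lowest number of the three. The step of a 3.8-fold lower number from compound 1 to compound 3 (0.59 log units; beyond the scatter) isolates the change on the oxygen, difluoromethyl in place of methyl on an oxygen on an aromatic ring, and shows that this small exchange at the end of the arm moves the number beyond the scatter, which the ring change alone had not revealed. Nothing measured here accounts for either step.

The compounds shown leave open whether the 5-methoxypyridin-2-yl ring would also gain from a difluoromethoxy group in place of its methoxy, since the step from compound 2 to compound 3 changes the ring and the oxygen substituent together. They also leave open how far the trend on the oxygen runs, for instance to a trifluoromethyl or an ethyl group there, and whether the same exchange holds when the phenylsulfonyl end of the molecule is changed.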